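Chloro to Bromo on the Benzyl Group

The compounds below may be only part of what the source reports. "The series", "measured", "known", "first", "only" and "open" are said of these compounds alone.

Measured compounds:
- compound 1, `O=c1c2cnn(-c3ccc(F)cc3)c2ncn1CC1(O)CCN(Cc2cccnc2)CC1`: "not determined" (no result reported) in an assay on Sf21 cells for inhibition of ubiquitin carboxyl-terminal hydrolase 7 (Homo sapiens), read by spectrophotometry, with stated times of 30 min and 2 h; on this read-out lower numbers stand for stronger inhibition and higher numbers for weaker inhibition
- compound 2, `COC(=O)c1ccc(CN2CCC(O)(Cn3cnc4c(cnn4-c4ccc(F)cc4)c3=O)CC2)c(Cl)c1`: 800 nM

For the measured compounds named here, compound 2 is the only compound with a number in this assay; compound 1 carries no result there, so nothing can be said about how the two compare. Compound 2 therefore stands alone as the reference point, and its value is the only anchor for what follows.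

Compound 3, `COC(=O)c1ccc(CN2CCC(O)(Cn3cnc4c(cnn4-c4ccc(F)cc4)c3=O)CC2)c(Br)c1`, is not yet measured. It differs from compound 2 in one place: bromo in place of chloro on an aromatic carbon. Going by the values given here, no pair of measured compounds shows a step of this kind, so the size of the step cannot be read from the data; it can only be framed as an expectation. A change of this sort, one halogen for another at the same aromatic carbon, is expected to move the result little, if at all, and not beyond the usual scatter of repeated measurements.

For compound 3 in this assay the expected value is 700 nM, with a range from 350 nM to 1400 nM, which means a step of a 1.1-fold lower number from compound 2 to compound 3 (0.06 log units; within the scatter) that is expected to stay within scatter.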

Compound 3, half-maximal inhibitory concentration: 900 nM
The estimate for compound 3 lay 1.3-fold (0.11 log units) below the measured number; low and high end bracket the measured number.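

In this assay, for the compounds shown here, the swap of chloro for bromo on the aromatic carbon ortho to a large group gives a 1.1-fold higher number from compound 2 to compound 3 (0.05 log units; within the scatter) and is the first comparison these compounds allow, since compound 1 has no number to set against compound 2. Within the scatter of repeated measurements, compound 2 and compound 3 cannot be told apart, so at this position on the benzyl group one of these halogens can stand in for the other without a detectable change in the read-out. No measurement shown explains this result, and none shows how either halogen acts at this position.

The compounds shown leave open whether this position accepts only a halogen or would also accept a quite different group, such as an amine or a methoxy group, or simply a hydrogen atom. They also leave open how much the methoxycarbonyl group, present in both compound 2 and compound 3, contributes, and whether a carboxylic acid or an amide in its place would give a different result.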